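Compound 1 to compound 4: butyl to 4-chlorophenyl

The source may hold more compounds than are shown below. What is called first, only, known or untested is meant among the compounds shown, and "the series" means these compounds.

In an ADME assay on Vero cells (Chlorocebus sabaeus) for cytotoxicity (on this read-out lower numbers stand for higher toxicity in this test and higher numbers for lower toxicity in this test), compound 1 (`CCCCNc1[nH]c2c(F)cc(F)cc2c(=O)c1C(C)=O`) gives > 25000 nM as a limit and not a number. Compound 2 (`CC(=O)c1c(OCc2ccc(Cl)c(Cl)c2)[nH]c2c(F)cc(F)cc2c1=O`) gives > 25000 nM and this is also a limit. Compound 3 (`COc1ccc(CNc2[nH]c3c(F)cc(F)cc3c(=O)c2C(C)=O)cc1`) gives > 25000 nM and this too is a limit. The measured set therefore comes down to the limit of > 25000 nM in this assay, at which 3 of the 3 values shown sit, and compound 1 has no exact position on the scale.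

Compound 4 (`CC(=O)c1c(Nc2ccc(Cl)cc2)[nH]c2c(F)cc(F)cc2c1=O`) carries 4-chlorophenyl in place of butyl on a nitrogen on an aromatic ring and the rest of the structure stays that of compound 1.

The closest measured change is a step that the two limits leave unreadable from compound 1 to compound 3 and it supplies no size to carry over. It does show that compound 3 stays at the limit with 4-methoxyphenyl in the side chain. Within the data shown here, no measured compound has an aromatic ring bound directly to that nitrogen, so a drop in the read-out cannot be excluded. Even so, no step beyond the scatter is expected in this assay on the present data. The expected step is a number no higher from compound 1 to compound 4 (the limit leaves the size open) and it remains an estimate. Compound 4 is expected at 25000 nM with an estimated range from 12000 nM to 50000 nM for now.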

Compound 4, half-maximal cytotoxic concentration: > 25000 nM
Compound 4: only a limit was reported; the forecaster's own chance of this, stated with the estimate: 70%; the middle value sits exactly at the limit.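

In this assay compound 4 gives > 25000 nM, which is a limit and not a number. Among these compounds, compound 1 also stands at a limit, so no step from compound 1 to compound 4 can be read. The compounds shown leave open whether these side chains differ at all in this assay, with every value at one limit: the limit of > 25000 nM in this assay, at which 4 of the 4 values shown sit.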